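The compounds below may be only part of what the source reports. "The series", "measured", "known", "first", "only" and "open" are said of these compounds alone.

Of the compounds shown here, three have been measured in a functional assay on NFS-60 cells (Mus musculus) for inhibition, with a stated time of 72 h; a lower number here means a stronger inhibitor of growth, a higher number a weaker inhibitor of growth. Compound 1 (`COc1ccc(Cn2nc(Br)c3c(NC(=O)c4csc5c(N)ncnc45)cccc32)cc1`) gives 2390 nM, compound 2 (`Nc1ncnc2c(C(=O)Nc3cccc4c3c(Br)nn4Cc3ccccn3)csc12`) gives 2500 nM, and compound 3 (`Nc1ncnc2c(C(=O)Nc3cccc4c3c(Br)nn4Cc3cccc(Br)n3)csc12`) gives 243 nM, the lowest of the three numbers. Compound 4 (`CCn1nc(Cn2nc(Br)c3c(NC(=O)c4csc5c(N)ncnc45)cccc32)cc1C(C)C`) changes the ring of compound 3: 1-ethyl-5-isopropyl-1H-pyrazol-3-yl in place of 6-bromopyridin-2-yl on a saturated chain carbon bound to an aromatic nitrogen. Earlier changes at this place differ in size. Pyridin-2-yl in place of 4-methoxyphenyl came with a 1.0-fold higher number from compound 1 to compound 2 (0.02 log units; within the scatter), whereas 6-bromopyridin-2-yl in its place came with a 9.8-fold lower number from compound 1 to compound 3 (0.99 log units; beyond the scatter). Adding the bromo alone came with a 10-fold lower number from compound 2 to compound 3 (1.01 log units; beyond the scatter). Within the data shown here, compound 4 lacks that bromo, and no measured compound carries its pyrazole, so only a small rise within the scatter is expected. The expected step is a 1.6-fold higher number from compound 3 to compound 4 (0.22 log units; within the scatter). For compound 4 the estimated value is 400 nM, with an expected range of 80 nM to 2000 nM.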

Compound 4, concentration for 50% growth inhibition: 62 nM
Compound 4: the middle estimate sits 6.5-fold (0.81 log units) above what was measured, and the stated range ends above it.
By their numbers in this assay, from the lowest: compound 4; then compound 3; then compounds 1 and 2 (each within the scatter of the next).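

Among these compounds, a ring at this place, on a saturated chain carbon bound to an aromatic nitrogen, need not be six-membered or carry a bromo: 1-ethyl-5-isopropyl-1H-pyrazol-3-yl in place of 6-bromopyridin-2-yl comes with a 3.9-fold lower number from compound 3 to compound 4 (0.59 log units; beyond the scatter) and is the first five-membered ring seen here. The same pyrazole comes with a 40-fold lower number from compound 2 to compound 4 (1.61 log units; beyond the scatter) when it replaces pyridin-2-yl, and with a 39-fold lower number from compound 1 to compound 4 (1.59 log units; beyond the scatter) when it replaces 4-methoxyphenyl. Nothing measured here explains these gains. 

The ethyl and isopropyl groups cannot be judged separately, as both arrive together. As far as these compounds go, what a pyrazole with methyl in place of isopropyl, or one carrying an amine, would give remains open.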